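A few compounds are considered here, and "the series" means these few. Any claim that something is new, unique, unknown or untested is made for them only; others in the source may bear on it.

Early results for this series come from a functional assay on SW1573 cells (Homo sapiens) for antiproliferative activity, read by sulforhodamine B assay, with a stated time of 48 h; a higher number here means a weaker inhibitor of growth, a lower number a stronger inhibitor of growth. Going by the values given here, there, compound 1 (`CCCCCC(C#CC(=O)OC)O/C=C/C(=O)OC`) gives 1700 nM and is the lower of the two numbers measured so far. Compound 2 (`C#CC(O/C=C/C(=O)OC)c1ccccc1`) gives 31000 nM in this assay, a gap beyond the usual scatter, so compound 1 is the stronger growth inhibitor of this pair.

The next compound to consider is compound 3 (`CCCC(C#CC(=O)OC)O/C=C/C(=O)OC`), which has not yet been measured. It differs from compound 1 in one place, where pentyl becomes propyl, a change counted as hydrogen in place of ethyl on a saturated chain carbon, four bonds along the chain from an oxygen on an unsaturated carbon and a triple-bonded carbon on a saturated chain carbon. Among the compounds with values here, compounds 1 and 2 differ in more than one place, so no measured step shows what shortening this chain does. The expectation therefore starts from compound 1 at 1700 nM and leans only a little towards compound 2 at 31000 nM on the higher side. The expected change is a modest one, a 2.4-fold higher number from compound 1 to compound 3 (0.37 log units; beyond the scatter) in this assay, towards somewhat weaker growth inhibition. For compound 3 the estimated value is 4000 nM with an expected range of 1300 nM to 13000 nM around that estimate.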

Compound 3, concentration for 50% growth inhibition: 320 nM
The estimate for compound 3 lay 13-fold (1.10 log units) above the measured number, outside the stated range (below it).
By their numbers in this assay, from the lowest: compound 3; then compound 1; then compound 2.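

Shortening pentyl to propyl, on a saturated chain carbon four bonds along the chain from an oxygen on an unsaturated carbon and a triple-bonded carbon, gives a 5.3-fold lower number from compound 1 to compound 3 (0.73 log units; beyond the scatter) in this assay. Going by these compounds alone, this is the first change in a single place to be read, and it shows that this chain affects growth inhibition by more than the usual scatter, with the shorter propyl chain giving the stronger inhibitor of this pair. No measurement shown here accounts for the gain in potency, so the step records what happens without explaining it.

Within the data shown here, a single step joins only two chain lengths, so it cannot show whether potency keeps rising as the chain shortens, peaks at propyl, or changes in some other way, and a butyl chain or a methyl group at this carbon would help to separate these possibilities. It also leaves open how a branched isopropyl group, a terminal hydroxyl or an amine on the chain would compare with propyl in this assay.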